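The source may report more compounds than this note shows. Statements on the series, on what has been measured and on what is new or still open speak of the compounds shown alone.

Three compounds share one core and were tested in an assay on LtK cells with ATP-sensitive inward rectifier potassium channel 11 (Homo sapiens) as the target; a lower number here means that less compound is needed, a higher number that more compound is needed for the effect. Compound 3 `O=C(Nc1c(C(O)(C(F)(F)F)C(F)(F)F)ccc2ccccc12)c1cccc([N+](=O)[O-])c1` gives 117 nM; compound 1 `CCCC(=O)Nc1c(C(O)(C(F)(F)F)C(F)(F)F)ccc2ccccc12` gives 131 nM and compound 2 `COCC(=O)Nc1c(C(O)(C(F)(F)F)C(F)(F)F)ccc2ccccc12` gives 213 nM. Compound 3 holds the lowest of the three numbers, yet its steps to the others lie within the scatter: a 1.1-fold lower number from compound 1 to compound 3 (0.05 log units; within the scatter) and a 1.8-fold lower number from compound 2 to compound 3 (0.26 log units; within the scatter). Compound 4 `O=C(Nc1c(C(O)(C(F)(F)F)C(F)(F)F)ccc2ccccc12)c1cccc(Cl)c1Cl` differs from compound 3 in one place: 2,3-dichlorophenyl in place of 3-nitrophenyl on a carbonyl carbon. Every measured step changes the group on the same carbonyl carbon, and none moves beyond the scatter, including a 1.6-fold higher number from compound 1 to compound 2 (0.21 log units; within the scatter), though none swaps one aromatic ring for another. For compound 4 the expectation is therefore no step beyond the scatter, a 1.0-fold higher number from compound 3 to compound 4 (0.01 log units; within the scatter). Compound 4 is estimated at 120 nM, between 50 nM and 300 nM.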

Compound 4, half-maximal effective concentration: > 10000 nM
Compound 4 ended at the assay's limit (the forecaster's own chance of this, stated with the estimate: 5%); middle value at least 83-fold (1.92 log units) away from the limit.
By their numbers in this assay, from the lowest: compounds 3, 1 and 2 (each within the scatter of the next). At a limit, above all of these: compound 4.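

Among the compounds shown here, the group on this carbonyl carbon matters more than the earlier compounds showed: propyl, methoxymethyl and 3-nitrophenyl gave values within the scatter of one another, whereas 2,3-dichlorophenyl brings an at least 85-fold higher number from compound 3 to compound 4 (1.93 log units; beyond the scatter), an at least 76-fold higher number from compound 1 to compound 4 (1.88 log units; beyond the scatter) and an at least 46-fold higher number from compound 2 to compound 4 (1.67 log units; beyond the scatter). An aromatic ring here does not by itself keep the number low, since compound 3 and compound 4 each carry one. The value of compound 4 is a limit of the assay, not a number: the limit of > 10000 nM in this assay, at which 1 of the 4 values shown sits.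

On these data alone, whether the chlorines or the missing nitro group drive this step stays open. A plain phenyl or a monochlorophenyl group on this carbon would help separate the two.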